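The source may report more compounds than this note shows. Statements on the series, on what has been measured and on what is new or still open speak of the compounds shown alone.

Solubility series on the shared core of compound 2 `CN(C)c1cccc(Oc2ccc3c(NCCCNCc4ccco4)ccnc3c2)c1`. In a physicochemical assay for solubility, with a stated time of 18 h, at pH 7.4 (a higher number here means a more soluble compound, a lower number a less soluble compound), compound 2 gives 14500 nM. Compound 1 `CC(C)(C)c1ccc(Oc2ccc3c(NCCCNCc4ccco4)ccnc3c2)cc1` gives 14500 nM and compound 3 `COc1cccc(CNCCCNc2ccnc3cc(Oc4cccc(N(C)C)c4)ccc23)c1O` gives 14500 nM, so compound 2 stands level with both at the digits shown, nearest to compound 1 and equally close to compound 3, all three within the scatter of one another.

The unmeasured compound 4 `c1ccc(-c2ccc3c(NCCCNCc4ccco4)ccnc3c2)cc1` differs from compound 2 by phenyl in place of 3-(dimethylamino)phenoxy on an aromatic carbon.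

Two measured steps are available. Of these, no change at the digits printed from compound 1 to compound 2 (within the scatter) changed the group on the ether oxygen and no change at the digits printed from compound 2 to compound 3 (within the scatter) changed the group on the amine nitrogen. Among the compounds with values here, neither removes the ether oxygen itself; the step to compound 4 therefore has no direct precedent. Both measured steps left the read-out flat, and the three values sit at the same level, which points to a step within the scatter, with perhaps a modest downward lean that the data cannot confirm.

Compound 4 is accordingly expected at 12000 nM, within 3000 nM to 30000 nM. The step of a 1.2-fold lower number from compound 2 to compound 4 (0.08 log units; within the scatter) is the estimated change, expected to lie within the scatter.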

Compound 4, solubility: 32000 nM
Estimate against measurement, compound 4: 2.7-fold (0.43 log units) below; the whole stated range lies below it.
By their numbers in this assay, from the lowest: compounds 1, 2 and 3 (each within the scatter of the next); then compound 4.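

In this assay, within the data shown here, the aromatic carbon carrying the 3-(dimethylamino)phenoxy group gives the first step beyond the scatter: phenyl in its place gives a 2.2-fold higher number from compound 2 to compound 4 (0.34 log units; beyond the scatter). The earlier steps shown here changed only the group on the ether oxygen or on the amine nitrogen and stayed within the scatter, whereas this change removes the ether oxygen and the dimethylamino group together, so the two are not separated here. No measurement on hand bears on the reason for the higher number.

Unsubstituted phenoxy, or phenyl carrying a dimethylamino group, at this carbon would show which of the two removed parts goes with the step. Also open, from the compounds shown here alone, is whether a morpholine or a carboxylic acid on the phenyl ring would move the number further, and whether the step holds with 2-hydroxy-3-methoxyphenyl in place of furan-2-yl.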